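Same Aryl Swap, Second Core: Cell Tolerance Expected

The source may report more compounds than this note shows. Statements on the series, on what has been measured and on what is new or still open speak of the compounds shown alone.

Of the compounds shown here, three have been measured in an ADME assay on U-937 cells (Homo sapiens) for cytotoxicity, read by MTT assay, with a stated time of 24 h; a lower number here means that less compound is tolerated, a higher number that more compound is tolerated. Compound 2 `CCc1ccc(OC(CCn2ccnc2)c2ccc(Cl)cc2)cc1` gives 265000 nM. Compound 1 `Clc1ccc(C(CCn2ccnc2)Oc2ccc(Cl)cc2Cl)cc1` differs from compound 2 in a single place, (2,4-dichlorophenyl in place of 4-ethylphenyl on an oxygen on a saturated carbon), and in this assay compound 1 gives 172000 nM, a step of a 1.5-fold lower number from compound 2 to compound 1 (0.19 log units; within the scatter). Compound 3 `CCc1ccc(OC(CCn2ccnc2)c2ccc(C)cc2)cc1` differs from compound 2 by methyl in place of chloro on an aromatic carbon, and in this assay compound 3 gives 152000 nM, a step of a 1.7-fold lower number from compound 2 to compound 3 (0.24 log units; within the scatter). All three numbers therefore lie close together, and none of them can be set apart from the others.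

Compound 4 `Cc1ccc(C(CCn2ccnc2)Oc2ccc(Cl)cc2Cl)cc1` has not yet been measured. It stands to compound 3 exactly as compound 1 stands to compound 2: the change is 2,4-dichlorophenyl in place of 4-ethylphenyl on an oxygen on a saturated carbon, the same change at the same place, carried out on a core that differs by methyl in place of chloro on an aromatic carbon. Because a 1.5-fold lower number from compound 2 to compound 1 (0.19 log units; within the scatter) stayed within the scatter, the step of a 1.3-fold lower number from compound 3 to compound 4 (0.10 log units; within the scatter) is expected to be of about that size. Compound 4 is thus estimated to give 120000 nM, most likely between 60000 nM and 250000 nM.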

Compound 4, half-maximal cytotoxic concentration: 150000 nM
Beside the measured number, compound 4's estimate is 1.3-fold (0.10 log units) below it; low and high end bracket the measured number.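

In this assay, the swap of 4-ethylphenyl for 2,4-dichlorophenyl on the second core gives a 1.0-fold lower number from compound 3 to compound 4 (0.01 log units; within the scatter), and it agrees with the same swap on the first core: the same change on two cores in this assay, a 1.5-fold lower number (0.19 log units; within the scatter) from compound 2 to compound 1 and a 1.0-fold lower number (0.01 log units; within the scatter) from compound 3 to compound 4, 1.5-fold (0.18 log units) apart, within the scatter of two such steps. Read the other way round the square of four compounds, methyl in place of chloro gives a 1.1-fold lower number from compound 1 to compound 4 (0.06 log units; within the scatter), and this too agrees with its earlier counterpart: the same change on two cores in this assay, a 1.7-fold lower number (0.24 log units; within the scatter) from compound 2 to compound 3 and a 1.1-fold lower number (0.06 log units; within the scatter) from compound 1 to compound 4, 1.5-fold (0.18 log units) apart, within the scatter of two such steps. Within the data shown here, both changes therefore look the same on either core, but every step is itself within the scatter, so this shows only that neither change has a visible effect here, not that a change with a clear effect would carry over from one core to another.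

The compounds shown leave open whether an amine or a carboxylic acid on an aromatic carbon, or a longer chain in place of the ethyl group, would move the number beyond the scatter. They also leave open whether such a step would then be the same size on both cores.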